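Anilide series: urea in place of dichlorobenzamide

The compounds below may be only part of what the source reports. "The series", "measured", "known", "first", "only" and "open" are said of these compounds alone.

Measured so far in an ADME assay on HS27 cells (Homo sapiens) for antiproliferative activity, read by MTT assay, with a stated time of 24 h; a higher number here means a weaker inhibitor, a lower number a stronger inhibitor:
- compound 1 `O=C(Nc1ccc(-n2ccc3c(NC(=O)c4ccccc4)ncnc32)cc1)c1ccc(Cl)c(Cl)c1` gives 5000 nM
- compound 2 `O=C(Nc1ccc(-n2ccc3c(NC(=O)c4ccccc4)ncnc32)cc1)c1cc(C(F)(F)F)cc(C(F)(F)F)c1` gives 6600 nM

Compound 1 holds the lower of the two numbers in this assay, but compound 2 sits close by, and the gap between them is within the scatter, so the two are read as equal. Going by the values given here, no step between measured compounds is available.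

Compound 3 `O=C(Nc1ccc(-n2ccc3c(NC(=O)c4ccccc4)ncnc32)cc1)Nc1cccc(C(F)(F)F)c1` is not yet measured. It differs from compound 1 by (3-(trifluoromethyl)phenyl)amino in place of 3,4-dichlorophenyl on a carbonyl carbon. Among the compounds with values here, nothing in the two measured numbers indicates how this assay responds to such a change; the only guide is that both measured amides land in the same region. Compound 3 is therefore expected to stay near that region, with a step from compound 1 of no change at the digits printed from compound 1 to compound 3 (within the scatter) in this assay, not beyond the scatter. The estimate for compound 3 in this assay is 5000 nM, within 1500 nM to 16000 nM.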

Compound 3, half-maximal inhibitory concentration: 4500 nM
Compound 3: the middle estimate sits 1.1-fold (0.05 log units) above what was measured; low and high end bracket the measured number.
By their numbers in this assay, from the lowest: compounds 3, 1 and 2 (each within the scatter of the next).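

In this assay, (3-(trifluoromethyl)phenyl)amino in place of 3,4-dichlorophenyl on a carbonyl carbon gives a 1.1-fold lower number from compound 1 to compound 3 (0.05 log units; within the scatter), so compound 3 reads as equal to compound 1. This position therefore accepts a urea as well as an amide without a step beyond the scatter, even though the entering group brings a hydrogen-bond donor that the leaving group lacks. Nothing on hand bears on why these compounds read alike.

From the compounds shown here alone, all three compounds carry a substituted phenyl ring on this side, so it remains open whether a piperidine or a carboxylic acid at the same carbonyl carbon would leave the number in the same region. The benzoyl group common to all three is also unchanged, which leaves open the effect of an acetyl group in its place.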